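The compounds below may be only part of what the source reports. "The series", "measured", "known", "first", "only" and "open" are said of these compounds alone.

Measured compounds, antiproliferative numbers:

Compound 1 `Fc1ccc(C2CC(c3ccccc3)=NN2c2ccc(-c3ccccc3)nn2)cc1`, in a functional assay on MCF7 cells (Homo sapiens) for antiproliferative activity, read by MTT assay, with a stated time of 24 h (on this read-out lower numbers stand for stronger inhibition and higher numbers for weaker inhibition), compound 1 gives 100000 nM.
Compound 2 `COc1ccc(C2=NN(c3ccc(-c4ccccc4)nn3)C(c3ccccc3)C2)cc1`, in this assay compound 2 reaches only the assay limit, > 100000 nM, which is not a number.
Compound 3 `COc1ccc(C2=NN(c3ccc(-c4ccccc4)nn3)C(c3ccc(Cl)cc3)C2)cc1`, in this assay compound 3 gives 58000 nM.

Compound 3 holds the lowest of the two actual numbers, but its nearest neighbour, compound 1, sits within the scatter of it, so no order between the two can be claimed. Compound 2 contributes only a limit (the limit of > 100000 nM in this assay, at which 1 of the 3 values shown sits).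

Compound 4 `COc1ccc(C2=NN(c3ccc(-c4ccccc4)nn3)C(c3ccc(F)cc3)C2)cc1` differs from compound 3 in one place: fluoro in place of chloro on an aromatic carbon. Among the measured compounds shown here, the only measured step touching this position is an at least 1.7-fold lower number from compound 2 to compound 3 (0.23 log units; that floor lies within the scatter), a change whose floor lies within the scatter; it says that putting chloro where hydrogen stood did not clearly move the number. For the measured compounds named here, a swap of chloro for fluoro on the same aromatic carbon has no measured counterpart here, and the one neighbouring step is itself small, so in this assay no step beyond the scatter is expected in either direction, with a slight lean toward a higher number given how close compound 2 and compound 3 already sit.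

Compound 4 is therefore expected at about 80000 nM, between 40000 nM and 160000 nM, an estimated step of a 1.4-fold higher number from compound 3 to compound 4 (0.14 log units; within the scatter) from compound 3, with a real chance that only a limit is returned.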

Compound 4, half-maximal inhibitory concentration: 20000 nM
Compound 4: the middle estimate sits 4.0-fold (0.60 log units) above what was measured; measured number outside the range, below it.
By their numbers in this assay, from the lowest: compound 4; then compounds 3 and 1 (each within the scatter of the next).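

In this assay, the change from 4-chlorophenyl to 4-fluorophenyl gives a clear move at this position, a 2.9-fold lower number from compound 3 to compound 4 (0.46 log units; beyond the scatter), so the choice of halogen matters here in a way that chloro in place of hydrogen, an at least 1.7-fold lower number from compound 2 to compound 3 (0.23 log units; that floor lies within the scatter), did not show. Fluoro in place of hydrogen on the same aromatic carbon also clears the scatter, an at least 5.0-fold lower number from compound 2 to compound 4 (0.69 log units; beyond the scatter), but this is only a floor, and compound 2 carries a limit rather than a number: the limit of > 100000 nM in this assay, at which 1 of the 4 values shown sits.

With the 4-fluorophenyl held fixed, methoxy in place of hydrogen on the other aromatic ring gives a 5.0-fold lower number from compound 1 to compound 4 (0.70 log units; beyond the scatter), which shows that a second place on the shared core also moves the number and leaves compound 4 with steps beyond the scatter to all three other compounds.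

Among the compounds shown here, this carbon is seen only with hydrogen, chloro and fluoro, so it remains open whether a hydroxyl, an amine or a trifluoromethyl would follow fluoro or chloro. On these data alone, it also remains open whether the methoxy step carries over to the 4-chlorophenyl compounds, or whether an ethoxy or a dimethylamino group in that place would do the same.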